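Swapping 3,4-difluorophenyl for 3,4-dichlorophenyl: a small step expected

The source may report more compounds than this note shows. Statements on the series, on what has been measured and on what is new or still open speak of the compounds shown alone.

In an ADME assay on Vero cells (Chlorocebus sabaeus) for cytotoxicity, read by MTT assay, with a stated time of 72 h (on this read-out lower numbers stand for higher toxicity in this test and higher numbers for lower toxicity in this test), compound 3 `CC1(C)C=Cc2c(ccc(C(=O)/C=C/c3ccc(F)c(F)c3)c2O)O1` gives 146000 nM and compound 1 `CC1(C)C=Cc2c(ccc(C(=O)/C=C/c3ccc(Cl)cc3)c2O)O1` gives 92200 nM, so the two cannot be told apart. For compound 2 `CC1(C)C=Cc2c(ccc(C(=O)/C=C/c3ccc(Br)cc3)c2O)O1` the result is "not determined" (no result reported). Compound 4 `CC1(C)C=Cc2c(ccc(C(=O)/C=C/c3ccc(Cl)c(Cl)c3)c2O)O1` is still unmeasured and differs from compound 3 by one change: 3,4-dichlorophenyl in place of 3,4-difluorophenyl on a double-bonded chain carbon bound to a double-bonded chain carbon. Among the measured compounds shown here, the only measured step that bears on this is a 1.6-fold higher number from compound 1 to compound 3 (0.20 log units; within the scatter), where 3,4-difluorophenyl took the place of 4-chlorophenyl. That step stays within the scatter, so no step beyond the scatter is expected here, at most a small drift toward compound 1 at 92200 nM. The expected step is a 1.5-fold lower number from compound 3 to compound 4 (0.16 log units; within the scatter). For compound 4 the estimated value is 100000 nM, with an expected range of 50000 nM to 200000 nM.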

Compound 4, half-maximal cytotoxic concentration: 142000 nM
Compound 4: the middle estimate sits 1.4-fold (0.15 log units) below what was measured; measured number inside the range.
By their numbers in this assay, from the lowest: compounds 1, 4 and 3 (each within the scatter of the next).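

In this assay the 3,4-dichlorophenyl group in place of 3,4-difluorophenyl gives a 1.0-fold lower number from compound 3 to compound 4 (0.01 log units; within the scatter) and so, at this place on the chain, chlorine and fluorine cannot be told apart. Chloro in place of hydrogen on an aromatic carbon gives a 1.5-fold higher number from compound 1 to compound 4 (0.19 log units; within the scatter) and so this added chloro also brings no clear change. Nothing measured here offers an explanation for these results.

Still open, going by these compounds, is whether a different kind of group on this aromatic ring, such as an amine or a carboxylic acid, would shift the number beyond the scatter.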